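The source may report more compounds than this note shows. Statements on the series, on what has been measured and on what is new or still open speak of the compounds shown alone.

Measured so far:
- compound 1 `CC(C)(C)C(=O)CN1C(=O)N(CC(=O)Nc2cccc(-c3nc(=O)o[nH]3)c2)N=C(C2CCCCC2)c2ccccc21`: 589 nM
- compound 2 `CC1CCCC1C(=O)CN1C(=O)N(CC(=O)Nc2cccc(C(=O)O)c2)N=C(C2CCCCC2)c2ccccc21`: 3980 nM

Both numbers come from an assay on CHO-K1 cells for displacement of a labelled ligand from Cholecystokinin receptor type A (Homo sapiens); a higher number here means a weaker inhibitor, a lower number a stronger inhibitor. Compound 1 holds the lower of the two values; compound 2 sits well above it, and the gap between them is beyond the scatter. Compound 2 differs from compound 1 in two places at once, so no single step can be read from the pair; the two values only show that the carboxylic acid variant with the methylcyclopentyl ketone side chain is the weaker of the two.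

Compound 3 `CN(CC(=O)O)c1cccc(NC(=O)CN2N=C(C3CCCCC3)c3ccccc3N(CC(=O)C(C)(C)C)C2=O)c1` keeps the side chain of compound 1 and changes only the group on the anilide ring: a group of 6 heavy atoms (3 carbon, 1 nitrogen, 2 oxygen; no ring) in place of a group of 6 heavy atoms (2 carbon, 2 nitrogen, 2 oxygen; one five-membered aromatic ring with 3 hetero atoms), on an aromatic carbon. Going by the values given here, no measured step of this kind exists, so the expectation rests on the two values alone. The carboxylic acid of compound 2 gives 3980 nM, which is the only hint that a carboxylic acid in this position may cost potency; the step from compound 1 to compound 3 is therefore expected to go toward a higher number, a 2.5-fold higher number from compound 1 to compound 3 (0.41 log units; beyond the scatter), probably beyond the scatter but not certainly so. Compound 3 is estimated at 1500 nM in this assay, with a plausible range from 300 nM to 7000 nM.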

Compound 3, inhibition constant: 6460 nM
Compound 3: middle estimate off by 4.3-fold (0.63 log units), on the low side; the measured number falls inside the stated range.
By their numbers in this assay, from the lowest: compound 1; then compounds 2 and 3 (each within the scatter of the next).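

In this assay, the position on the six-membered aromatic ring of carbon only, meta to a large group, responds strongly to the group it carries: with the side chain held constant, (carboxymethyl)(methyl)amino in place of the five-membered aromatic ring with 3 hetero atoms gives an 11-fold higher number from compound 1 to compound 3 (1.04 log units; beyond the scatter) as a large step. Going by these compounds alone, this is the first change that can be read at a single place, since compound 1 and compound 2 differ in both the side chain and the anilide ring group. The entering and leaving groups have the same count of heavy atoms, so that count alone does not preserve the value, and no measurement at hand gives a reason for the step.

Still open, on these data alone, is whether the step follows the loss of the ring or the presence of the carboxymethyl chain, which a plain dimethylamino group or an amine at this position would help to separate. A carboxylic acid set directly on the ring, paired with the side chain of compound 1, and a longer chain between the nitrogen and the acid would also give single-place comparisons.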